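Dichlorophenyl enters where pyrimidinyl sat, at a potency floor

A few compounds are considered here, and "the series" means these few. Any claim that something is new, unique, unknown or untested is made for them only; others in the source may bear on it.

Of the compounds shown here, three built on a shared core have been tested in an assay on HEK293 cells for inhibition of sodium-dependent dopamine transporter (Homo sapiens), read by scintillation counting; on this read-out lower numbers stand for stronger inhibition and higher numbers for weaker inhibition. Compound 1 `O=C(NCCCN1CCN(c2cccc(Cl)c2Cl)CC1)c1cc(Cl)cc(Cl)c1` carries a 3,5-dichlorophenyl on the carbonyl carbon and a 2,3-dichlorophenyl on the ring nitrogen. In this assay compound 1 gives > 10000 nM, which is a limit of the assay and not a number. Compound 2 `O=C(NCCCN1CCN(c2cccc(Cl)c2Cl)CC1)c1cccc2ccccc12` keeps the same ring-nitrogen group and changes only the group on the carbonyl carbon. In this assay compound 2 gives > 10000 nM, again a limit. The step that the two limits leave unreadable from compound 1 to compound 2 therefore has no readable size. Compound 3 `O=C(NCCCN1CCN(c2ncccn2)CC1)c1ccc2ccccc2n1` carries a pyrimidin-2-yl on the ring nitrogen and differs from the others in both aryl groups. In this assay compound 3 gives > 10000 nM, also a limit, so compound 3 stands with the other two at the limit of > 10000 nM in this assay, at which 3 of the 3 values shown sit. Compound 4 `O=C(NCCCN1CCN(c2cccc(Cl)c2Cl)CC1)c1ccc2ccccc2n1` arises from compound 3 through (2,3-dichlorophenyl in place of pyrimidin-2-yl on an amine nitrogen in a ring). Among the compounds with values here, no measured step matches this change, and a step that the two limits leave unreadable from compound 1 to compound 2 offers no readable size for comparison, while the entering 2,3-dichlorophenyl is the very group compounds 1 and 2 carry at the limit. Compound 4 is therefore expected to stay near the limit, with an expected step that the limit leaves unreadable from compound 3 to compound 4. The estimate for compound 4 in this assay is 15000 nM, within a range from 3000 nM to 60000 nM.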

Compound 4, half-maximal inhibitory concentration: > 10000 nM
Compound 4: no number, only a limit; the forecaster's own chance of this, stated with the estimate: 75%; the middle value lies beyond the limit too.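

Compound 4 gives [ > 10000 nM ], a limit of the assay and not a number. Its steps from compound 1, compound 2 and compound 3 therefore cannot be read: the limit of > 10000 nM in this assay, at which 4 of the 4 values shown sit.

The compounds shown leave open how far any of these changes moves the potency, and which change on the shared core would give a readable value.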